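The source may hold more compounds than are shown below. What is called first, only, known or untested is meant among the compounds shown, and "the series" means these compounds.

Of the compounds shown here, three sharing one core have so far been measured in a functional assay on MKN-45 cells (Homo sapiens) for cytotoxicity, read by MTT assay, with a stated time of 72 h; a lower number here means a stronger inhibitor, a higher number a weaker inhibitor. Compound 1 `CN(C)CCn1cnnc1-c1cc(Oc2ccc(NC(=O)N/N=C/c3cccc(Br)c3)cc2F)ccn1` gives 450 nM, compound 2 `CN(C)CCn1cnnc1-c1cc(Oc2ccc(NC(=O)N/N=C/c3ccc(F)cc3Cl)cc2F)ccn1` gives 870 nM, and compound 3 `COc1ccc(/C=N/NC(=O)Nc2ccc(Oc3ccnc(-c4nncn4CCN(C)C)c3)c(F)c2)cc1O` gives 2510 nM, the highest number of the three. Compound 4 `COc1cc(/C=N/NC(=O)Nc2ccc(Oc3ccnc(-c4nncn4CCN(C)C)c3)c(F)c2)cc(OC)c1OC` differs from compound 3 only at one place: 3,4,5-trimethoxyphenyl in place of 3-hydroxy-4-methoxyphenyl on a carbon with a double bond to nitrogen. Two earlier swaps at that same carbon bear on this step, namely a 5.6-fold higher number from compound 1 to compound 3 (0.75 log units; beyond the scatter) and a 2.9-fold higher number from compound 2 to compound 3 (0.46 log units; beyond the scatter), both modest. Both involve halogenated aryl groups rather than a trimethoxyphenyl, so they give no clear direction for the new change. A step of a 1.2-fold higher number from compound 3 to compound 4 (0.08 log units; within the scatter) is expected, within the scatter. Compound 4 is therefore estimated at 3000 nM, with a range from 1000 nM to 9000 nM.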

Compound 4, half-maximal inhibitory concentration: 2900 nM
The estimate for compound 4 lay 1.0-fold (0.01 log units) above the measured number, within the range that was stated.
By their numbers in this assay, from the lowest: compounds 1 and 2 (each within the scatter of the next); then compounds 3 and 4 (each within the scatter of the next).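

Replacing 3-hydroxy-4-methoxyphenyl with 3,4,5-trimethoxyphenyl takes this position from 1 hydrogen-bond donor to 0 and adds heavy atoms, yet the number stays within the scatter (a 1.2-fold higher number from compound 3 to compound 4 (0.06 log units; within the scatter)). The new group also sits clearly above both halogen-bearing aryl groups (a 3.3-fold higher number from compound 2 to compound 4 (0.52 log units; beyond the scatter); a 6.4-fold higher number from compound 1 to compound 4 (0.81 log units; beyond the scatter)), so among these four compounds, both oxygen-bearing aryl groups give higher numbers than both halogen-bearing ones, with none going against this. No supporting evidence is available to explain this split.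

From the compounds shown here alone, how a phenyl ring carrying an amine or a carboxylic acid would behave on this carbon remains open.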